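Tolerance in Mouse Cells: Swapping One Amine Substituent

The source may report more compounds than this note shows. Statements on the series, on what has been measured and on what is new or still open speak of the compounds shown alone.

Compound 2, `COC(CNC1Oc2ccc(C(=O)c3ccccc3)c(O)c2NC1c1ccccc1)OC`, carries a (2,2-dimethoxyethyl)amino group on the shared core. In a functional assay on HT-22 cells (Mus musculus), read by MTT assay (a lower number here means that less compound is tolerated, a higher number that more compound is tolerated), compound 2 gives > 250 uM, which is a limit of the assay and not a number. Compound 1, `CN(CC1OCCO1)C1Oc2ccc(C(=O)c3ccccc3)c(O)c2NC1c1ccccc1`, differs from compound 2 only at that amine substituent. In this assay compound 1 gives > 250 uM, again a limit. The step that the two limits leave unreadable from compound 1 to compound 2 therefore cannot be sized. Compound 3, `CC(C)CNC1Oc2ccc(C(=O)c3ccccc3)c(O)c2NC1c1ccccc1`, has not yet been measured; it differs from compound 2 by isopropyl in place of dimethoxymethyl on a saturated chain carbon bound to an amine nitrogen. Among the measured compounds shown here, the single measured step is unreadable, so no size for this change can be drawn from the numbers. What the data do show is the limit of > 250 uM in this assay, at which 2 of the 2 values shown sit, which points to tolerance up to the limit for both measured compounds. Compound 3 is therefore expected to be tolerated to a similar degree. The step expected here, an at least 1.2-fold lower number from compound 2 to compound 3 (0.09 log units; that floor lies within the scatter), is none beyond the scatter. For compound 3 the estimate in this assay is 200 uM, within 80 uM to 400 uM.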

Compound 3, half-maximal toxic concentration: 108 uM
Compound 3: middle estimate off by 1.9-fold (0.27 log units), on the high side; the measured number falls inside the stated range.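

In this assay, this position now shows a readable effect: isopropyl in place of dimethoxymethyl on a saturated chain carbon bound to an amine nitrogen gives an at least 2.3-fold lower number from compound 2 to compound 3 (0.36 log units; beyond the scatter) and so moves the number by more than ordinary scatter. Isobutylamino in place of ((1,3-dioxolan-2-yl)methyl)(methyl)amino gives a step of the same printed size, an at least 2.3-fold lower number from compound 1 to compound 3 (0.36 log units; beyond the scatter) and thus the amine substituent can change how much compound the cells tolerate. Both steps are only floors, because the two starting compounds each stop at a limit of the assay and not at a number: the limit of > 250 uM in this assay, at which 2 of the 3 values shown sit.

Going by these compounds, how far the number would fall with a longer chain in place of isopropyl remains open. So does whether a carboxylic acid or a second amine on this chain would keep the number at the limit or lower it.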